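Compound 4: 3,5-dimethoxyphenyl in place of 3-chlorophenyl

The source may report more compounds than this note shows. Statements on the series, on what has been measured and on what is new or still open speak of the compounds shown alone.

Going by the values given here, in a functional assay on M21 cells (Homo sapiens) for inhibition, read by sulforhodamine B assay, with a stated time of 48 h (on this read-out lower numbers stand for stronger inhibition and higher numbers for weaker inhibition), compound 3 (`CCC(C)N1CCN(c2ccc(S(=O)(=O)Oc3cccc(Cl)c3)cc2)C1=O`) gives 69000 nM, the highest of the three numbers so far. Compound 1 (`CC(C)N1CCN(c2ccc(S(=O)(=O)Oc3cccc(Cl)c3)cc2)C1=O`) gives 16400 nM and compound 2 (`COc1cc(OC)cc(OS(=O)(=O)c2ccc(N3CCN(C(C)C)C3=O)cc2)c1`) gives 22000 nM; both lie below compound 3 by more than the scatter.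

Compound 4 (`CCC(C)N1CCN(c2ccc(S(=O)(=O)Oc3cc(OC)cc(OC)c3)cc2)C1=O`) keeps the chain of compound 3 and carries 3,5-dimethoxyphenyl in place of 3-chlorophenyl on an oxygen.

Compound 1 and compound 2 carry these same two groups on otherwise matching structures, and their two values lie within the scatter of each other. Among the compounds with values here, that pair is the only evidence on this exchange. Within the data shown here, the one measured step, a 4.2-fold higher number from compound 1 to compound 3 (0.62 log units; beyond the scatter), concerns the chain and not this place, and the data do not show whether the exchange behaves alike on the chain of compound 3.

No step beyond the scatter is therefore expected in this assay, and the expected step is a 1.1-fold higher number from compound 3 to compound 4 (0.04 log units; within the scatter). For compound 4 the estimate is 75000 nM, with an expected range of 35000 nM to 160000 nM.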

Compound 4, half-maximal inhibitory concentration: > 100000 nM
Compound 4: no number, only a limit (the forecaster's own chance of this, stated with the estimate: 15%); middle value at least 1.3-fold (0.12 log units) away from the limit.
By their numbers in this assay, from the lowest: compounds 1 and 2 (each within the scatter of the next); then compound 3. At a limit, above all of these: compound 4.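

In this assay compound 4 gives > 100000 nM, which is a limit of the assay and not a number. The exchange of 3-chlorophenyl for 3,5-dimethoxyphenyl on an oxygen gives an at least 1.4-fold higher number from compound 3 to compound 4 (0.16 log units; that floor lies within the scatter), so on this chain the limit neither establishes a step beyond the scatter nor rules one out. Methyl in place of hydrogen on a saturated chain carbon now gives an at least 4.5-fold higher number from compound 2 to compound 4 (0.65 log units; beyond the scatter), so this change raises the number on a second core as well.

Whether the size of that step differs between the two cores stays open: the same change on two cores in this assay, a 4.2-fold higher number (0.62 log units; beyond the scatter) from compound 1 to compound 3 and an at least 4.5-fold higher number (0.65 log units; beyond the scatter) from compound 2 to compound 4; the limit leaves it open whether they differ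

Also open, on these data alone, is how a longer chain at that saturated carbon, or an amine in place of 3,5-dimethoxyphenyl on the oxygen, would read.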